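A few compounds are considered here, and "the series" means these few. Any claim that something is new, unique, unknown or untested is made for them only; others in the source may bear on it.

Measured compounds:
compound 1 `COc1ccccc1-c1cn(-c2ccc(O)c(C(=O)Nc3cccc(C(F)(F)F)c3)c2)nn1` gives 65% in a functional assay on CCRF-CEM cells (Homo sapiens) for inhibition, read by MTT assay, with a stated time of 2 days, tested at 10 uM; a lower number here means less inhibition, a higher number more inhibition at the concentration tested (going by the name of the read-out);
compound 2 `COc1cc(OC)cc(-c2cn(-c3ccc(O)c(C(=O)OCCCc4ccccc4)c3)nn2)c1` gives 8% in this assay;
compound 3 `COc1ccccc1-c1cn(-c2ccc(O)c(C(=O)OCCCc3ccccc3)c2)nn1` gives 4% in this assay.

Compound 3 and compound 1 differ in one place: (3-(trifluoromethyl)phenyl)amino in place of 3-phenylpropoxy on a carbonyl carbon. This change made a large step, a number 61 percentage points higher from compound 3 to compound 1 (beyond the scatter). Compound 2 and compound 3 share everything but the group on the triazole, where (3,5-dimethoxyphenyl in place of 2-methoxyphenyl on an aromatic carbon); their values differ only within the scatter, a number 4 percentage points lower from compound 2 to compound 3 (within the scatter).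

Compound 4 `COc1cc(OC)cc(-c2cn(-c3ccc(O)c(C(=O)Nc4cccc(C(F)(F)F)c4)c3)nn2)c1` is not yet measured in this assay. It stands to compound 2 as compound 1 stands to compound 3: (3-(trifluoromethyl)phenyl)amino in place of 3-phenylpropoxy on a carbonyl carbon. The place lines of the two changes agree word for word, so this is the same change, here made on the core of compound 2 instead of the core of compound 3. The two cores differ only as described above, and that difference hardly moved the value.

Compound 4 is therefore expected to gain about as much as compound 1 did, and a step of roughly a number 58 percentage points higher from compound 2 to compound 4 (beyond the scatter) is estimated, resting on compound 3 and its step of a number 61 percentage points higher from compound 3 to compound 1 (beyond the scatter) together with the value of compound 2, 8%. The estimate for compound 4 in this assay is 66%, expected to lie between 45% and 85%.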

Compound 4, a percentage reported as inhibition, at one concentration (the size of the read-out at that concentration, not a potency): 73%
The estimate for compound 4 lay 7 percentage points below the measured number; low and high end bracket the measured number.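

Replacing 3-phenylpropoxy with (3-(trifluoromethyl)phenyl)amino on the carbonyl carbon carried over from one core to the other in this assay, giving a number 65 percentage points higher from compound 2 to compound 4 (beyond the scatter), in line with the earlier step: the same change on two cores in this assay, a number 61 percentage points higher (beyond the scatter) from compound 3 to compound 1 and a number 65 percentage points higher (beyond the scatter) from compound 2 to compound 4, 4 percentage points apart, within the scatter of two such steps. With the new group in place, the other difference, 3,5-dimethoxyphenyl in place of 2-methoxyphenyl on an aromatic carbon, stayed within the scatter, at a number 8 percentage points higher from compound 1 to compound 4 (within the scatter), just as it had with 3-phenylpropoxy: the same change on two cores in this assay, a number 4 percentage points lower (within the scatter) from compound 2 to compound 3 and a number 8 percentage points lower (within the scatter) from compound 4 to compound 1, 4 percentage points apart, within the scatter of two such steps. This shows that the change transferred between these two closely related cores, but it rests on four compounds read at a single concentration, so it shows nothing about other cores or about potency.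

The compounds shown leave open what a 3-phenylpropylamino chain, a plain phenylamino group or a carboxylic acid would give at the same carbonyl carbon, so the part played by the nitrogen cannot be separated from that of the trifluoromethyl-bearing ring. Also open, from the compounds shown here alone, is how an unsubstituted phenyl or a saturated cyclohexyl group on the triazole would behave.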